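Swapping chloro for trifluoromethyl in a series

The source may hold more compounds than are shown below. What is called first, only, known or untested is meant among the compounds shown, and "the series" means these compounds.

Compound 1 `CC(Oc1ccc(Oc2ccc(Cl)cc2)cc1)C(=O)Cn1nnc(-c2ccccc2)n1` in an ADME assay on S9 fraction from liver (Rattus norvegicus) for metabolic stability, read by LC-MS, using NADPH, with a stated time of 30 min (a higher number here means that more of the compound is left, a lower number that less of the compound is left), gives < 5%, which is a limit of the assay and not a number.
Compound 2 `CC(Oc1ccc(Oc2ccc(C(F)(F)F)cc2)cc1)C(=O)Cn1nnc(-c2ccccc2)n1` in this assay gives 6%.
Compound 3 `CC(Oc1ccc(Oc2ccc(Cl)cc2)cc1)C(=O)Cn1nnc(-c2ccc(Cl)cc2)n1` in this assay gives < 5%, again a limit and not a number.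

All three measured compounds are broken down almost completely under these conditions. Compound 4 `CC(Oc1ccc(Oc2ccc(C(F)(F)F)cc2)cc1)C(=O)Cn1nnc(-c2ccc(Cl)cc2)n1` has not been measured yet. It differs from compound 3 by trifluoromethyl in place of chloro on an aromatic carbon. Exactly the same change, at the same place, has already been made once within this set: compound 2 differs from compound 1 by trifluoromethyl in place of chloro on an aromatic carbon, and in this assay the result was a number at least 1 percentage points higher from compound 1 to compound 2 (that floor lies within the scatter). The two cores, that of compound 1 and that of compound 3, differ by chloro in place of hydrogen on an aromatic carbon; in this assay this gives a step that the two limits leave unreadable from compound 1 to compound 3, because of the limit of < 5% in this assay, at which 2 of the 3 values shown sit.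

For compound 4 the expected step is a number at least 1 percentage points higher from compound 3 to compound 4 (that floor lies within the scatter). That expectation rests on compound 2, which gives 6% after the same change. Compound 4 is expected to give 6%, with a likely range from 2% to 14%. Whether the assay reports a number or only a limit for compound 4 is close to an even chance.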

Compound 4, percent of the compound remaining: 9%
The estimate for compound 4 lay 3 percentage points below the measured number; low and high end bracket the measured number.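

In this assay, carrying trifluoromethyl in place of chloro over to the core of compound 3 gives a number at least 4 percentage points higher from compound 3 to compound 4 (that floor lies within the scatter). Neither this floor nor the one on the core of compound 1 goes beyond the usual scatter, so the data show no clear rise on either core, but they also do not show that the change does nothing or that it behaves alike on both cores: the same change on two cores in this assay, a number at least 1 percentage points higher (that floor lies within the scatter) from compound 1 to compound 2 and a number at least 4 percentage points higher (that floor lies within the scatter) from compound 3 to compound 4; the limit leaves it open whether they differ Chloro in place of hydrogen, readable only between the two trifluoromethyl compounds, gives a number 3 percentage points higher from compound 2 to compound 4 (within the scatter), while the same change between the two chloro compounds cannot be read: the limit of < 5% in this assay, at which 2 of the 4 values shown sit.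

The compounds shown vary only chloro, trifluoromethyl and hydrogen on aromatic carbons, and all of them remain close to the bottom of the range of this assay, so a single swap of this kind has not yet shown how much of a compound in this series can be left at the end. From the compounds shown here alone, what a quite different group at the same place would do, such as an amine, a nitrile or a carboxylic acid, stays open, as does the effect of changing the carbonyl or the chain that carries it.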